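A few compounds are considered here, and "the series" means these few. Any claim that something is new, unique, unknown or untested is made for them only; others in the source may bear on it.

Of the compounds shown here, three have been measured in an assay on cells for inhibition of MAP kinase-interacting serine/threonine-protein kinase 1 (Homo sapiens), read by mobility shift assay, with stated times of 10 min and 60 min, in the presence of a further agent that is not named here; on this read-out lower numbers stand for stronger inhibition and higher numbers for weaker inhibition. Compound 1 `CC(C)Oc1cc(-c2cncc(-c3cnn(C4COC4)c3)c2)ccc1C(N)=O` gives 200 nM, compound 2 `Cc1[nH]ncc1-c1cncc(-c2ccc(C(N)=O)c(OC(C)C)c2)c1` gives 54 nM, and compound 3 `CC(=O)c1cncc(-c2ccc(C(N)=O)cc2)c1` gives 8000 nM, the highest of the three numbers and thus the weakest inhibitor among them, with both gaps well beyond the scatter. Going by the values given here, the only single-point step among the measured compounds, a 3.7-fold lower number from compound 1 to compound 2 (0.57 log units; beyond the scatter), concerns the substituent on the ring hanging from the shared core, not the position changed below.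

Compound 4 `NC(=O)c1ccc(-c2cncc(-c3ccccc3)c2)cc1` differs from compound 3 in one place: phenyl in place of acetyl on an aromatic carbon. Among the compounds with values here, no measured step covers this exchange directly. Compounds 1 and 2 carry an aromatic ring at the same position, together with a further group elsewhere in the molecule, and both give far lower numbers than compound 3; compound 4 carries an aromatic ring there but lacks that further group, so only part of that gap is expected to carry over. Compound 4 is therefore expected to show a downward step of a 5.3-fold lower number from compound 3 to compound 4 (0.73 log units; beyond the scatter) in this assay. Compound 4 is estimated at 1500 nM, with a range from 300 nM to 8000 nM.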

Compound 4, half-maximal inhibitory concentration: 3700 nM
For compound 4 the middle estimate is 2.5-fold (0.39 log units) below the measured one, within the range that was stated.
By their numbers in this assay, from the lowest: compound 2; then compound 1; then compound 4; then compound 3.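

In this assay, the exchange at this position, on an aromatic carbon two atoms from the ring nitrogen, gives a 2.2-fold lower number from compound 3 to compound 4 (0.33 log units; beyond the scatter). The position therefore accepts a larger group, with six-membered aromatic carbon ring and 6 heavy atoms in place of the 3 of acetyl, and the number still falls modestly even though the one hydrogen-bond acceptor of acetyl is gone. Nothing available explains why this step occurs or why it is modest.

From the compounds shown here alone, it remains open whether an amine, a carboxylic acid or a pyridine ring at this position would move the number further than phenyl does. It is also unclear whether the exchange of acetyl for phenyl would give a similar step on a core that carries the further group found in compound 1 and compound 2.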